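Amide substituent variation on the shared core

A few compounds are considered here, and "the series" means these few. Any claim that something is new, unique, unknown or untested is made for them only; others in the source may bear on it.

Measured so far:
compound 1 `CCN(CC)CCNC(=O)c1ccc(C(CC)(CC)c2ccc(OCC(O)C(C)(C)C)c(C)c2)n1CC`: 110 nM
compound 2 `CCn1c(C(=O)N(C)CCC#N)ccc1C(CC)(CC)c1ccc(OCC(O)C(C)(C)C)c(C)c1`: 1960 nM

Among the measured compounds shown here, in an assay on HL-60 cells for agonist activity at vitamin D3 receptor (Homo sapiens), read by microscopy, with a stated time of 96 h (a lower number here means that less compound is needed, a higher number that more compound is needed for the effect), compound 2 gives 1960 nM, the highest of the two numbers so far; the nearest is compound 1, and the step between them is an 18-fold higher number from compound 1 to compound 2 (1.25 log units; beyond the scatter), a large one, beyond the scatter. Compound 3 `CCn1c(C(=O)Nc2ccc(OC(F)(F)F)cc2)ccc1C(CC)(CC)c1ccc(OCC(O)C(C)(C)C)c(C)c1` has not been measured. It differs from compound 2 only at the carbonyl carbon: (4-(trifluoromethoxy)phenyl)amino in place of (2-cyanoethyl)(methyl)amino on a carbonyl carbon. For the measured compounds named here, the one measured step that bears on this position is an 18-fold higher number from compound 1 to compound 2 (1.25 log units; beyond the scatter), which shows that exchanging the group on this carbonyl carbon can shift the number by a large amount. Going by the values given here, no measured compound carries an aromatic ring on that nitrogen, so the direction rests on a single precedent; the entering group brings one hydrogen-bond donor where the leaving group has none, and a lower number is expected for compound 3, though with wide uncertainty. Compound 3 is estimated at 450 nM, with a range from 90 nM to 2200 nM. The expected step is a 4.4-fold lower number from compound 2 to compound 3 (0.64 log units; beyond the scatter).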

Compound 3, half-maximal effective concentration: > 50000 nM
Compound 3 gave a limit, no number (the forecaster's own chance of this, stated with the estimate: 5%); middle value at least 110-fold (2.04 log units) from the limit.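

In this assay compound 3 gives a limit and not a number: the limit of > 50000 nM in this assay, at which 1 of the 3 values shown sits. Among the compounds shown here, until now the series showed only that the group on this carbonyl carbon can move the number, and (4-(trifluoromethoxy)phenyl)amino now gives an at least 25-fold higher number from compound 2 to compound 3 (1.40 log units; beyond the scatter), the opposite direction to that expected from the amide hydrogen it brings. On the same amide-type nitrogen, 4-(trifluoromethoxy)phenyl in place of 2-(diethylamino)ethyl gives an at least 450-fold higher number from compound 1 to compound 3 (2.65 log units; beyond the scatter); both compounds keep the amide hydrogen, so that hydrogen alone does not hold the number low, and the group it shares the nitrogen with matters far more.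

As far as these compounds go, the true size of both steps stays open, as does whether the loss belongs to the aromatic ring itself or to its trifluoromethoxy group. A plain phenyl on that nitrogen would separate those two, and a 2-(dimethylamino)ethyl chain would show whether the low number of compound 1 tolerates a smaller amine.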